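Swapping ring substituents on a sparingly soluble core

A few compounds are considered here, and "the series" means these few. Any claim that something is new, unique, unknown or untested is made for them only; others in the source may bear on it.

Measured compounds:
compound 1, `Cc1cc(NCc2ccccn2)n2ncc(-c3c(C)cccc3C)c2n1`: < 5000 nM
compound 2, `Cc1cc(NCC2CCCCN2)n2nc(C)c(-c3ccccc3)c2n1`: 189000 nM

Of the compounds shown here, two have been tested in a physicochemical assay for solubility, read by HPLC, using the shake flask method, measured as kinetic solubility, with a stated time of 2 h, at pH 7.4; on this read-out higher numbers stand for higher solubility and lower numbers for lower solubility. For compound 1 the result < 5000 nM is a limit of the assay and not a number, so only a ceiling is known for it, as the limit of < 5000 nM in this assay, at which 1 of the 2 values shown sits, records. Within the data shown here, compound 2 gives 189000 nM in this assay, but its structure differs from compound 1 in several places at once, so the two values show only that compound 2 is far more soluble and nothing about any single change.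

Compound 3, `Cc1cc(NCc2ccccn2)n2ncc(-c3ccc(F)cc3C)c2n1`, has not yet been measured. It differs from compound 1 by 4-fluoro-2-methylphenyl in place of 2,6-dimethylphenyl on an aromatic carbon. Among the measured compounds shown here, because compound 1 sits at the limit of < 5000 nM in this assay, at which 1 of the 2 values shown sits, there is no measured step that tells how such a swap moves solubility. The change exchanges one small group for another of the same size and the same count of donors and acceptors, so no shift beyond the scatter is expected from compound 1 to compound 3. Compound 3 is therefore expected to give about 4000 nM, within 1000 nM to 15000 nM, and may again fall at the limit. The expected step that the limit leaves unreadable from compound 1 to compound 3 is small.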

Compound 3, solubility: 42300 nM
Estimate against measurement, compound 3: 11-fold (1.02 log units) below, outside the stated range (above it).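

In this assay, among these compounds, 4-fluoro-2-methylphenyl in place of 2,6-dimethylphenyl on this aromatic carbon gives an at least 8.4-fold higher number from compound 1 to compound 3 (0.92 log units; beyond the scatter), the first single change whose effect can be read at all. The two groups have equal counts of heavy atoms, hydrogen-bond donors and hydrogen-bond acceptors, and each is one six-membered aromatic ring of carbon only, so a swap that leaves all of these counts unchanged can still shift this read-out beyond the usual scatter. The value for compound 1 is a limit and not a number, so the step is only a minimum and its true size remains unknown: the limit of < 5000 nM in this assay, at which 1 of the 3 values shown sits.

The compounds shown do not separate the added fluorine from the lost methyl, and so it remains open which of the two accounts for the step, or whether both are needed. Also open, going by these compounds, is how this read-out would respond to other groups on the same phenyl ring, such as a chlorine, a methoxy group or an amine, and whether the same swap would act alike with a different side chain on the shared core.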